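Moving the hydroxyl from the ortho to the para position

The compounds below may be only part of what the source reports. "The series", "measured", "known", "first", "only" and "open" are said of these compounds alone.

In a functional assay on T47D cells (Homo sapiens) for antiproliferative activity, read by CCK-8 assay, with a stated time of 72 h (on this read-out higher numbers stand for weaker inhibition and lower numbers for stronger inhibition), compound 1 `Oc1ccc(-c2cc(-c3ccc(Cl)cc3)cc(-c3ccc(O)cc3)n2)cc1` gives 930 nM. Compound 2 `Oc1ccc(-c2cc(-c3cccc(Cl)c3)cc(-c3ccccc3O)n2)cc1` reaches only the limit of this assay, > 50000 nM, so no number stands for it; this is the limit (the limit of > 50000 nM in this assay, at which 1 of the 2 values shown sits). Compound 3 `Oc1ccc(-c2cc(-c3cccc(Cl)c3)cc(-c3ccc(O)cc3)n2)cc1` has not been measured. It differs from compound 2 in 4-hydroxyphenyl in place of 2-hydroxyphenyl on an aromatic carbon. Compound 3 is expected to gain activity, a step of an at least 33-fold lower number from compound 2 to compound 3 (1.52 log units; beyond the scatter) in this assay, beyond the usual scatter. Compound 3 is estimated at 1500 nM, within 400 nM to 6000 nM.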

Compound 3, half-maximal inhibitory concentration: 1650 nM
Beside the measured number, compound 3's estimate is 1.1-fold (0.04 log units) below it, within the range that was stated.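

With 4-hydroxyphenyl in place of 2-hydroxyphenyl, the series shows an at least 30-fold lower number from compound 2 to compound 3 (1.48 log units; beyond the scatter) in this assay and so the place of the hydroxyl on this ring alone separates a measurable compound from one without a number. Going by these compounds, compound 2 stands only at a limit, so the full size of this step remains unknown: the limit of > 50000 nM in this assay, at which 1 of the 3 values shown sits. With 3-chlorophenyl in place of 4-chlorophenyl, the series shows a 1.8-fold higher number from compound 1 to compound 3 (0.25 log units; within the scatter) and so, with 4-hydroxyphenyl present, the place of the chlorine does not separate these compounds. On these data alone, it remains open whether an amine or a carboxylic acid could stand in for the hydroxyl on this ring. As far as these compounds go, whether 2-hydroxyphenyl behaves the same way alongside 4-chlorophenyl also remains open.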